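Methyl in Place of Fluorine on the Aryl Ether

The source may report more compounds than this note shows. Statements on the series, on what has been measured and on what is new or still open speak of the compounds shown alone.

Within the data shown here, compound 3 `O=C(O)c1csc([C@H]2CC[C@@H]3[C@@H](COc4ccc(F)cc4)[C@H](O)C[C@@H]3O2)n1` gives 7 nM in a functional assay on CHO cells for agonist activity at prostaglandin E2 receptor EP2 subtype (Homo sapiens), read by HTRF and cAMP accumulation, with a stated time of 30 min (a higher number here means that more compound is needed for the effect, a lower number that less compound is needed), the lowest of the three numbers measured so far. Compound 1 `O=C(O)c1csc([C@H]2CC[C@@H]3[C@@H](COc4ccccc4F)[C@H](O)C[C@@H]3O2)n1` gives 23 nM and compound 2 `Cc1ccc(OC[C@@H]2[C@H]3CC[C@H](c4nc(C(=O)O)cs4)O[C@H]3C[C@H]2O)cc1` gives 27 nM; the step of a 3.3-fold lower number from compound 1 to compound 3 (0.52 log units; beyond the scatter) and the step of a 3.9-fold lower number from compound 2 to compound 3 (0.59 log units; beyond the scatter) both lie beyond the scatter, so compound 3 stands clearly apart from the other two. Compound 4 `Cc1cccc(OC[C@@H]2[C@H]3CC[C@H](c4nc(C(=O)O)cs4)O[C@H]3C[C@H]2O)c1` differs from compound 3 by 3-methylphenyl in place of 4-fluorophenyl on an oxygen on a saturated carbon. Among the measured compounds shown here, two measured steps bear on this change. The step of a 3.9-fold lower number from compound 2 to compound 3 (0.59 log units; beyond the scatter) shows that a methyl in place of a fluoro on an aromatic carbon gave a higher number, and the step of a 3.3-fold lower number from compound 1 to compound 3 (0.52 log units; beyond the scatter) shows that 4-fluorophenyl and 2-fluorophenyl differ by a modest amount as well. For the measured compounds named here, no measured pair shows a 3-methylphenyl, so the size of the step is uncertain. Compound 4 is therefore expected to give a modestly higher number than compound 3, with an estimated step of a 2.9-fold higher number from compound 3 to compound 4 (0.46 log units; beyond the scatter). Compound 4 is estimated at 20 nM, with a range from 7 nM to 60 nM.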

Compound 4, half-maximal effective concentration: 3.6 nM
Compound 4: the middle estimate sits 5.6-fold (0.74 log units) above what was measured, and the stated range ends above it.
By their numbers in this assay, from the lowest: compounds 4 and 3 (each within the scatter of the next); then compounds 1 and 2 (each within the scatter of the next).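

In this assay the change to 3-methylphenyl in place of 4-fluorophenyl gives a 1.9-fold lower number from compound 3 to compound 4 (0.29 log units; within the scatter) and so leaves the number unchanged within the scatter, showing that a methyl-bearing phenyl on this oxygen can match the 4-fluorophenyl, which compound 2 had not shown. The placing of the methyl matters here, since 3-methylphenyl in place of 4-methylphenyl gives a 7.5-fold lower number from compound 2 to compound 4 (0.88 log units; beyond the scatter) and 3-methylphenyl in place of 2-fluorophenyl gives a 6.4-fold lower number from compound 1 to compound 4 (0.81 log units; beyond the scatter) as well. No measurement is at hand that explains these steps.

The compounds shown leave open how a 3-fluorophenyl would compare with the 3-methylphenyl and the 4-fluorophenyl. They also leave open whether a larger group in the same place, such as 3-methoxyphenyl or 3-chlorophenyl, would keep the number of compound 4.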